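Trifluoromethyl isomer of compound 3: stability notes

The source may hold more compounds than are shown below. What is called first, only, known or untested is meant among the compounds shown, and "the series" means these compounds.

In an ADME assay on microsomes from liver (Homo sapiens) for metabolic stability, read by LC-MS, using NADPH, with a stated time of 30 min, tested at 3 uM (on this read-out higher numbers stand for a more stable compound and lower numbers for a less stable compound), compound 1 (`O=C1NCc2ncc(-c3ccc(-c4cncc(NS(=O)(=O)c5ccc(F)cc5F)c4)s3)cc21`) reads 95% and compound 2 (`COc1ncc(-c2ccc(-c3cnc4c(c3)CN(C)C4=O)s2)cc1NS(=O)(=O)c1ccc(F)cc1F`) reads 75% on the same scale. Compound 3 (`CN1Cc2cc(-c3ccc(-c4cncc(NS(=O)(=O)c5cccc(C(F)(F)F)c5)c4)s3)cnc2C1=O`) reads 46% as the lowest of the three numbers, and both other compounds lie above it beyond the scatter. Among the measured compounds shown here, these three differ in more than one place, so they offer no single-change step to work from.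

Compound 4 (`CN1Cc2cc(-c3ccc(-c4cncc(NS(=O)(=O)c5ccccc5C(F)(F)F)c4)s3)cnc2C1=O`) carries 2-(trifluoromethyl)phenyl in place of 3-(trifluoromethyl)phenyl on a sulfonyl sulfur with the same atoms joined differently. For the measured compounds named here, the only anchor for an expectation is compound 3 at 46% as the nearest measured structure, and no measured pair shows what this kind of change does. The expected change in this assay is small and upward, with an estimated a number 4 percentage points higher from compound 3 to compound 4 (within the scatter) that stays within the scatter. Compound 4 is expected at 50% within an estimated range from 30% to 72% in this read-out.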

Compound 4, percent of the compound remaining: 56%
Compound 4: the middle estimate sits 6 percentage points below what was measured; low and high end bracket the measured number.
By their numbers in this assay, from the lowest: compounds 3 and 4 (each within the scatter of the next); then compound 2; then compound 1.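

Among the compounds shown here, compounds 3 and 4 form the first single-change pair. In this assay, 2-(trifluoromethyl)phenyl in place of 3-(trifluoromethyl)phenyl on a sulfonyl sulfur gives a number 10 percentage points higher from compound 3 to compound 4 (within the scatter), so the two isomers cannot be told apart on this read-out and this change of attachment on the aryl group resolves no difference here. No supporting data bear on the reason for this result.

The pair covers only these two trifluoromethyl isomers on the shared core, so a methyl group, a longer alkyl chain or an amine-bearing phenyl on the sulfonyl sulfur remains an open case. As far as these compounds go, whether the same swap would also stay within the usual scatter on the core of compound 1 or of compound 2 also remains open.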